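Trimming the cyclohexyl group of compound 3

This account rests on a few compounds, and the source may have more. Where it says the series, first, only, none or still open, it means among the compounds named here.

Values measured so far in a physicochemical assay for lipophilicity, using the shake flask method (a lower number here means a more polar compound, a higher number a more lipophilic compound), are these.
- compound 1 `CCO/N=C/c1c(N)ncnc1Oc1ccc(NC(=O)C2(C(=O)Nc3ccc(F)cc3)CC2)cc1F` gives 3.41
- compound 2 `CC(C)(C)OC(=O)N/N=C/c1c(N)ncnc1Oc1ccc(NC(=O)C2(C(=O)Nc3ccc(F)cc3)CC2)cc1F` gives 3.7
- compound 3 `Nc1ncnc(Oc2ccc(NC(=O)C3(C(=O)Nc4ccc(F)cc4)CC3)cc2F)c1/C=N/OC1CCCCC1` gives 4.69

Compound 3 stands highest of the three, and its gaps to both others lie beyond the scatter. The next compound is compound 4 `CCCCO/N=C/c1c(N)ncnc1Oc1ccc(NC(=O)C2(C(=O)Nc3ccc(F)cc3)CC2)cc1F` which keeps the shared core and changes one group, butyl in place of cyclohexyl on an oxygen and nothing else.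

The closest guide is a change on that same oxygen, cyclohexyl in place of ethyl, which showed a number 1.28 log units higher from compound 1 to compound 3 (beyond the scatter) in this assay and is the main evidence here. The other two steps, a number 0.29 log units higher from compound 1 to compound 2 (within the scatter) and a number 0.99 log units higher from compound 2 to compound 3 (beyond the scatter) alter the whole group on the double-bonded nitrogen, so they say less. Butyl is a longer chain than ethyl but smaller than cyclohexyl, so compound 4 is expected to land in the span from compound 1 at 3.41 to compound 3 at 4.69 in all likelihood. A modest fall is therefore expected, estimated as a number 0.49 log units lower from compound 3 to compound 4 (beyond the scatter) on this reasoning. The estimated value for compound 4 is 4.2 with a range of 3.8 to 4.6 until a measurement settles it.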

Compound 4, partition coefficient: 4.2
Compound 4: middle estimate and measured number agree at the digits printed; the range from low to high includes it.
By their numbers in this assay, from the lowest: compounds 1 and 2 (each within the scatter of the next); then compound 4; then compound 3.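

On the oxygen, this assay now has a middle point between the two earlier groups: lengthening the chain gives a number 0.79 log units higher from compound 1 to compound 4 (beyond the scatter), and replacing the ring with the open chain gives a number 0.49 log units lower from compound 3 to compound 4 (beyond the scatter), so ethyl, butyl and cyclohexyl fall in that order, with each gap beyond the scatter. Butyl differs from cyclohexyl both in its carbon count, 4 against 6, and in having no ring, so this single step cannot show how much of the change goes with size and how much with the ring. The new compound also separates from the group with the tert-butoxycarbonyl unit, with a number 0.50 log units higher from compound 2 to compound 4 (beyond the scatter), whereas the ethoxy compound did not, with a number 0.29 log units higher from compound 1 to compound 2 (within the scatter).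

No measurement here gives a reason for any of these steps. Still open, going by these compounds, is whether a longer open chain such as hexyl would reach the level of the ring, and whether an amine or a carboxylic acid at the end of the butyl chain would bring the number back down.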